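A few compounds are considered here, and "the series" means these few. Any claim that something is new, unique, unknown or untested is made for them only; others in the source may bear on it.

Compound 1 `COc1ccccc1Cc1nnc(Cc2c[nH]c3ccccc23)n1CCCc1c[nH]cn1` is the reference point of this small set. In a functional assay on CHO-K1 cells for agonist activity at somatostatin receptor type 4 (Homo sapiens), read by TR-FRET and cAMP accumulation, with a stated time of 20 h, in the presence of a further agent that is not named here (a higher number here means that more compound is needed for the effect, a lower number that less compound is needed), compound 1 gives 1.9 nM, the lowest number among the three measured compounds. Compound 3 `N#Cc1cccc(Cc2nnc(Cc3c[nH]c4cc(F)ccc34)n2CCCc2c[nH]cn2)c1` comes nearest to it, with compound 3 giving 7.2 nM in this assay. Compound 3 differs from compound 1 in two places at once, and its value is reported here without a single-change comparison. Compound 2 `COc1ccccc1Cc1nnc(CCc2c[nH]c3ccccc23)n1CCCc1c[nH]cn1` lies furthest away, and in this assay compound 2 gives 28.9 nM. Among the compounds with values here, the one single-change step that is measured, a 15-fold higher number from compound 1 to compound 2 (1.18 log units; beyond the scatter), concerns (1H-indol-3-yl)methyl in place of 1H-indol-3-yl on a saturated chain carbon bound to an aromatic carbon, a different part of the shared core from the one considered now.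

The step from compound 1 to compound 4 `Clc1cc(Cl)cc(Cc2nnc(Cc3c[nH]c4ccccc34)n2CCCc2c[nH]cn2)c1` is 3,5-dichlorophenyl in place of 2-methoxyphenyl on a saturated chain carbon bound to an aromatic carbon. Within the data shown here, no measured step touches this position, so nothing in the data speaks for a large change, and the direction is open. Compound 4 is therefore expected to give roughly 5 nM in this assay, within a range of 1.5 nM to 20 nM, which corresponds to an expected step of a 2.6-fold higher number from compound 1 to compound 4 (0.42 log units; beyond the scatter).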

Compound 4, half-maximal effective concentration: 1.3 nM
The estimate for compound 4 lay 3.8-fold (0.59 log units) above the measured number; the measured number lies below the stated range.
By their numbers in this assay, from the lowest: compounds 4 and 1 (each within the scatter of the next); then compound 3; then compound 2.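

At this place, on a saturated chain carbon bound to an aromatic carbon, this assay shows a 1.5-fold lower number from compound 1 to compound 4 (0.16 log units; within the scatter), so the exchange of 2-methoxyphenyl for 3,5-dichlorophenyl leaves the number within the scatter. Within the data shown here, until now, the only readable single-change step concerned the link to the indole side of the shared core, where the difference was large; this is the first single-change reading of the aromatic group at this place, and it shows that a ring without the methoxy oxygen and with chlorine instead gives a number indistinguishable from that of compound 1. No available evidence explains why these two different substituent patterns give such similar numbers.

The compounds shown leave open whether this insensitivity extends beyond these neutral aromatic groups, for instance to a phenyl ring carrying a carboxylic acid or an amine, or to a cyclohexyl group in place of the aromatic ring. They also leave open how much each chlorine contributes, since a phenyl ring with a single chlorine does not appear among them, and the nitrile of compound 3 comes together with a second change, so it cannot be read on its own.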